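A few compounds are considered here, and "the series" means these few. Any claim that something is new, unique, unknown or untested is made for them only; others in the source may bear on it.

Measured compounds:
Compound 1 `O=C(Nc1cccc2nonc12)N1CCN(Cc2cccc(Oc3ccc(Cl)cc3)c2)CC1` gives 28 nM in an assay on isolated protein for inhibition of Fatty-acid amide hydrolase 1 (Homo sapiens), with a stated time of 60 min; a lower number here means a stronger inhibitor, a higher number a weaker inhibitor.
Compound 2 `O=C(Nc1noc2cnccc12)N1CCN(Cc2cccc(Oc3ccc(Cl)cc3)c2)CC1` gives 0.5 nM in this assay.

Compound 2 stands at the lowest of the two numbers in this assay; its nearest neighbour is compound 1, reached by the step of a 56-fold lower number from compound 1 to compound 2 (1.75 log units; beyond the scatter), which lies well beyond the scatter. Compound 3 `O=C(Nc1cccn2ccnc12)N1CCN(Cc2cccc(Oc3ccc(Cl)cc3)c2)CC1` has not yet been measured. It differs from compound 2 by a group of 9 heavy atoms (7 carbon, 2 nitrogen; one five-membered aromatic ring with 2 hetero atoms, one six-membered aromatic ring with 1 hetero atom) in place of a group of 9 heavy atoms (6 carbon, 2 nitrogen, 1 oxygen; one five-membered aromatic ring with 2 hetero atoms, one six-membered aromatic ring with 1 hetero atom), on an amide-type nitrogen; both bicyclic groups carry the same count of atoms, and the entering one holds one acceptor fewer. Among the measured compounds shown here, only one measured step bears on this change, the exchange of the bicyclic group on the amide-type nitrogen from compound 1 to compound 2, and that step was large. It shows that this position is sensitive to the identity of the bicyclic group, but compound 3 carries a third group of its own, so the direction cannot be read from it directly. Compound 3 is therefore expected to give a higher number than compound 2, with an estimated step of a 10-fold higher number from compound 2 to compound 3 (1.00 log units; beyond the scatter), landing around 5 nM and plausibly anywhere between 0.8 nM and 40 nM.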

Compound 3, half-maximal inhibitory concentration: 310 nM
Estimate against measurement, compound 3: 62-fold (1.79 log units) below, outside the stated range (above it).
By their numbers in this assay, from the lowest: compound 2; then compound 1; then compound 3.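

In this assay, the exchange on the amide-type nitrogen gives a 620-fold higher number from compound 2 to compound 3 (2.79 log units; beyond the scatter), although the leaving and entering groups have the same heavy-atom count and the same description of their rings, one five-membered aromatic ring with 2 hetero atoms and one six-membered aromatic ring with 1 hetero atom. Among the compounds shown here, compound 3 also lies on the weak side of compound 1, by an 11-fold higher number from compound 1 to compound 3 (1.04 log units; beyond the scatter), so compound 3 is the weakest of the three and this position separates the three bicyclic groups widely, not only the pair seen earlier. Nothing available here accounts for these differences.

The compounds shown leave open which feature of the bicyclic group governs the number, since the group in compound 3 holds no oxygen and also differs from the group in compound 2 in how its atoms are arranged. They also leave open whether a methyl, a methoxy group or a fluorine on the group of compound 3 would move its number in this assay, and how a simple amine on the carbonyl carbon would compare with these bicyclic groups.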